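Cyano for chloro on the amide phenyl of an aminothiazole

The source may hold more compounds than are shown below. What is called first, only, known or untested is meant among the compounds shown, and "the series" means these compounds.

Measured so far:
- compound 1, `CCOC(=O)c1sc(-c2cccc(NC(=O)c3cccc(F)c3)c2)nc1Nc1ccc(N2CCN(C)CC2)cc1`: 21200 nM in a functional assay on Raji cells (Homo sapiens) for antiproliferative activity, read by CCK-8 assay, with a stated time of 72 h; a lower number here means a stronger inhibitor, a higher number a weaker inhibitor
- compound 2, `CCOC(=O)c1sc(-c2cccc(NC(=O)c3ccc(Cl)cc3)c2)nc1Nc1ccc(N2CCN(C)CC2)cc1`: "not determined" (no result reported)

Compound 1 carries a fluoro on the benzamide ring, and in this assay compound 1 gives 21200 nM, a weak result. Compound 2 has the same core with a chloro instead, and for compound 2 this assay holds no single number, so nothing can be said about where it stands relative to compound 1. Within the data shown here, no step between measured compounds is available from these two entries.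

Compound 3, `CCOC(=O)c1sc(-c2cccc(NC(=O)c3ccc(C#N)cc3)c2)nc1Nc1ccc(N2CCN(C)CC2)cc1`, differs from compound 2 in one place: cyano in place of chloro on an aromatic carbon. Cyano in place of chloro on an aromatic carbon is a small swap on the outer benzamide ring, far from the rest of the molecule. Among the measured compounds shown here, with no number for compound 2, the only anchor is compound 1, whose 21200 nM suggests this series is weak in this assay. Compound 3 is therefore expected to remain weak, with an estimated 20000 nM, in a range from 5000 nM to 80000 nM, and the chance of only a limit being reported cannot be ruled out.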

Compound 3, half-maximal inhibitory concentration: 14000 nM
Compound 3: middle estimate off by 1.4-fold (0.15 log units), on the high side; measured number inside the range.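

In this assay the outer benzamide ring shows a 1.5-fold lower number from compound 1 to compound 3 (0.18 log units; within the scatter) when 4-cyanophenyl replaces 3-fluorophenyl on the carbonyl carbon, so this change of both the group and its place on the ring gives no difference that can be told from the ordinary spread of repeated measurements. Compound 3 thus adds a second readable value to the series, and neither compound 1 nor compound 3 can be ranked over the other. The step from compound 2 to compound 3, the direct exchange of chloro for cyano, cannot be read, and no measurement at hand offers an explanation for these values.

Going by these compounds, whether an amine, a carboxylic acid or a methoxy group on this ring would give a number clearly apart from these remains open, as does where the 4-chlorophenyl compound itself would stand. The rest of the molecule is the same in all the compounds shown, so what a change elsewhere on the shared core would do is also unknown.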